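Opening of an Enol Ether Cinnamyl Series toward an Aldehyde

The source may report more compounds than this note shows. Statements on the series, on what has been measured and on what is new or still open speak of the compounds shown alone.

Measured compounds:
compound 1, `COc1cc(/C=C/C=O)cc(OC)c1OCc1ccccc1`, 640000 nM
compound 2, `CC/C(C)=C/Oc1c(OC)cc(/C=C/CO)cc1OC`, 7800 nM

In a functional assay on KB cells (Homo sapiens) for cytotoxicity, with a stated time of 72 h (a lower number here means a stronger inhibitor, a higher number a weaker inhibitor), compound 1 gives 640000 nM, while compound 2 gives 7800 nM. Of the two numbers, compound 2 has the lower one, and the gap to compound 1 is far beyond the scatter; the two compounds differ in more than one place, so only their values can be compared.

Compound 3 is `CC/C(C)=C/Oc1c(OC)cc(/C=C/C=O)cc1OC`. It keeps the enol ether and the core of compound 2 and changes one group: formyl in place of hydroxymethyl on a double-bonded chain carbon bound to a double-bonded chain carbon. Going by the values given here, no measured pair shows this exact change, so there is no step to lean on. Given that the enol ether is shared and compound 2 stands at 7800 nM, the expected change in this assay is a modest step toward a lower number, estimated at a 2.6-fold lower number from compound 2 to compound 3 (0.41 log units; beyond the scatter). A result within the scatter would not surprise. Compound 3 is therefore estimated at 3000 nM, within 500 nM to 20000 nM.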

Compound 3, half-maximal inhibitory concentration: 5300 nM
For compound 3 the middle estimate is 1.8-fold (0.25 log units) below the measured one, within the range that was stated.
By their numbers in this assay, from the lowest: compounds 3 and 2 (each within the scatter of the next); then compound 1.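

Putting formyl in place of hydroxymethyl on a double-bonded chain carbon bound to a double-bonded chain carbon gives a 1.5-fold lower number from compound 2 to compound 3 (0.17 log units; within the scatter) in this assay, so with the enol ether in place, these two groups cannot be told apart at this position. With formyl held constant, 2-methylbut-1-en-1-yl in place of benzyl on an oxygen on an aromatic ring gives a 120-fold lower number from compound 1 to compound 3 (2.08 log units; beyond the scatter), so the large gap in this series follows the group on that oxygen rather than the chain end. Nothing available explains either result.

As far as these compounds go, it remains open whether a carboxylic acid or an amine at the chain end would separate from formyl and hydroxymethyl. Also open, from the compounds shown here alone, is how a longer chain on that oxygen would compare with 2-methylbut-1-en-1-yl.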